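The source may hold more compounds than are shown below. What is called first, only, known or untested is meant among the compounds shown, and "the series" means these compounds.

Compound 1 `O=S(=O)(Nc1ccc(-c2nc3ccccc3o2)cc1)c1ccc(Cl)s1`: in an assay on isolated protein for inhibition of malate dehydrogenase, mitochondrial (Sus scrofa), with stated times of 45 min and 30 min (a higher number here means a weaker inhibitor, a lower number a stronger inhibitor), compound 1 gives > 63000 nM, which is a limit of the assay.
Compound 2 `O=S(=O)(Nc1ccc(-c2nc3ccccc3o2)cc1)c1cccc(Cl)c1`: in this assay compound 2 gives > 63000 nM, again a limit of the assay.

Compound 2 thus stands only at a limit. For the measured compounds named here, the single measured step, a step that the two limits leave unreadable from compound 1 to compound 2, cannot be read in size, as the limit of > 63000 nM in this assay, at which 2 of the 2 values shown sit, shows. Compound 3 `O=S(=O)(Nc1ccc(-c2nc3ccccc3o2)cc1)c1ccccc1O` differs from compound 2 by 2-hydroxyphenyl in place of 3-chlorophenyl on a sulfonyl sulfur. Going by the values given here, no measured step is readable, so the expected step is a step that the limit leaves unreadable from compound 2 to compound 3, none beyond the scatter, and the read-out will most probably again be a limit. Compound 3 is therefore estimated at 100000 nM, within a range from 30000 nM to 300000 nM.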

Compound 3, half-maximal inhibitory concentration: > 63000 nM
Compound 3: no number, only a limit; the forecaster's own chance of this, stated with the estimate: 80%; the middle value is on the limit's open side.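

For the compounds shown here, compound 3 gives > 63000 nM in this assay and this too is a limit of the assay, so no step among compound 1, compound 2 and compound 3 can be read. From the compounds shown here alone, how strongly any of the three inhibits the enzyme, and how their groups on the sulfonyl sulfur compare, stays open.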